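Aryl amine variation on a shared diterpenoid-type core

The source may report more compounds than this note shows. Statements on the series, on what has been measured and on what is new or still open speak of the compounds shown alone.

Measured compounds:
compound 1, `C=C1[C@@H](OC(C)=O)C[C@@H]2[C@](C)(CO[Si](C)(C)C(C)(C)C)[C@H](OC(C)=O)CC[C@@]2(C)[C@@H]1C[C@@H](Nc1ccccc1)C1=CCOC1=O` — 5710 nM
compound 2, `C=C1[C@@H](OC(C)=O)C[C@@H]2[C@](C)(CO[Si](C)(C)C(C)(C)C)[C@H](OC(C)=O)CC[C@@]2(C)[C@@H]1C[C@@H](Nc1ccc(OC)cc1)C1=CCOC1=O` — 5630 nM
compound 3, `C=C1[C@@H](OC(C)=O)C[C@@H]2[C@](C)(COC=O)[C@H](OC(C)=O)CC[C@@]2(C)[C@@H]1C[C@@H](Nc1ccccc1C(=O)O)C1=CCOC1=O` — 42500 nM

In a functional assay on KB cells (Homo sapiens) for cytotoxicity, read by sulforhodamine B assay (on this read-out lower numbers stand for stronger inhibition and higher numbers for weaker inhibition), compound 3 gives the highest of the three numbers; compound 1 and compound 2 both lie well beyond the scatter from it. Compound 3 differs from compound 1 in more than one place, so nothing can be said about which part of the structure carries that gap.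

Compound 4, `C=C1[C@@H](OC(C)=O)C[C@@H]2[C@](C)(COC=O)[C@H](OC(C)=O)CC[C@@]2(C)[C@@H]1C[C@@H](Nc1ccc(C(=O)O)cc1)C1=CCOC1=O`, is unmeasured. It differs from compound 3 as follows: 4-carboxyphenyl in place of 2-carboxyphenyl on an amine nitrogen; the two have the same atoms, joined differently.

Among the measured compounds shown here, the only single-point step measured, a 1.0-fold lower number from compound 1 to compound 2 (0.01 log units; within the scatter), concerns a change on the aromatic ring of the aryl amine and lay within the scatter. For the measured compounds named here, no step moves a carboxyl around that ring, so it bears only loosely here. Going by the values given here, with that as the sole guide, compound 4 is expected to stay close to compound 3, with a step of a 1.1-fold lower number from compound 3 to compound 4 (0.03 log units; within the scatter) in this assay. Compound 4 is therefore estimated at 40000 nM, within a range of 15000 nM to 100000 nM.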

Compound 4, half-maximal inhibitory concentration: > 50000 nM
Compound 4 was reported as a limit; the forecaster's own chance of this, stated with the estimate: 10%; middle value at least 1.2-fold (0.09 log units) away from the limit.
By their numbers in this assay, from the lowest: compounds 2 and 1 (each within the scatter of the next); then compound 3. At a limit, above all of these: compound 4.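

In this assay compound 4 is reported only as a limit, > 50000 nM. Moving the carboxyl on the aryl amine, the change not covered by the earlier single-point step, gives an at least 1.1-fold higher number from compound 3 to compound 4 (0.07 log units; that floor lies within the scatter), so only a floor for the step is known and its true size stays open. With the rest of the structure held fixed, 4-carboxyphenyl in place of 2-carboxyphenyl on the amine nitrogen does not lower the number, and the reading rests at the assay limit: the limit of > 50000 nM in this assay, at which 1 of the 4 values shown sits.

Still open, from the compounds shown here alone, is how much of the weak reading of these two compounds belongs to the carboxylic acid itself and how much to the rest of the structure. A methyl ester or a primary amide in place of the carboxylic acid, on the core of compound 4, would address this directly.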